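Notes on the step from compound 3 to compound 4

The source may report more compounds than this note shows. Statements on the series, on what has been measured and on what is new or still open speak of the compounds shown alone.

Measured so far in a functional assay on PA-1 cells (Homo sapiens) for antiproliferative activity, read by MTT assay, with a stated time of 48 h (a lower number here means a stronger inhibitor, a higher number a weaker inhibitor), as follows
Compound 1 `CCN1C(=O)C(O)(Cc2nnn[nH]2)c2ccccc21` gives > 100000 nM as a limit
Compound 2 `CCN1C(=O)C(O)(Cc2nnn[nH]2)c2cc(Br)ccc21` gives > 100000 nM as a limit
Compound 3 `Cc1ccc2c(c1)C(O)(Cc1nnn[nH]1)C(=O)N2C` gives > 100000 nM as a limit

Compound 3 stands at > 100000 nM in this assay and this is a limit and not a number. Compound 1 and compound 2 are also reported only as limits. Among the measured compounds shown here, the series so far therefore rests on the limit of > 100000 nM in this assay, at which 3 of the 3 values shown sit, and no order among the three compounds can be read.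

Compound 4 `CCN1C(=O)C(O)(Cc2nnn[nH]2)c2cc(C)ccc21` differs from compound 3 by methyl in place of hydrogen on a saturated chain carbon bound to an amide-type nitrogen in a ring and the same difference reads methyl to ethyl. For the measured compounds named here, the one measured step is a step that the two limits leave unreadable from compound 1 to compound 2 and it concerns bromo in place of hydrogen on an aromatic carbon. That is a different change and it gives no size to carry over.

The expectation rests on compound 3 at > 100000 nM as a limit, with no readable step to shift it. The expected step is a step that the limit leaves unreadable from compound 3 to compound 4 and nothing beyond the scatter is expected in either direction. Compound 4 is estimated at 130000 nM with an expected range from 50000 nM to 350000 nM and a report as a limit only is the likeliest outcome.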

Compound 4, half-maximal inhibitory concentration: > 100000 nM
Compound 4 was reported as a limit; the forecaster's own chance of this, stated with the estimate: 90%; the middle value lies beyond the limit too.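

In this assay compound 4 gives > 100000 nM, which is a limit and not a number. No new step can be read from compound 1, compound 2 or compound 3 to compound 4. The compounds shown leave open whether any change on the shared core gives a readable value, as the series still rests on a single limit: the limit of > 100000 nM in this assay, at which 4 of the 4 values shown sit.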